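The compounds below may be only part of what the source reports. "The series", "measured", "known", "first", "only" and "open" are said of these compounds alone.

In an ADME assay on cells (Homo sapiens) for cytotoxicity, read by polymerase chain reaction, with a stated time of 3 days (on this read-out lower numbers stand for higher toxicity in this test and higher numbers for lower toxicity in this test), compound 1 `Nc1nc(Cl)c(-c2ccco2)c(N[C@@H]2C[C@H](CO)[C@@H](O)[C@H]2O)n1` gives only a limit, > 25000 nM. Compound 2 `Nc1nc(Cl)c(-c2nc3ccccc3o2)c(N[C@@H]2C[C@H](CO)[C@@H](O)[C@H]2O)n1` gives 12000 nM, and compound 3 `CCOCCNc1nc(C)c(-c2nc3ccccc3s2)c(N[C@@H]2C[C@H](CO)[C@@H](O)[C@H]2O)n1` gives 18000 nM. Among the measured compounds shown here, the one measured step is an at least 2.0-fold lower number from compound 1 to compound 2 (0.31 log units; beyond the scatter), a change on the aromatic ring. Compound 3 holds the highest of the two numbers shown, and its gap to compound 2 lies within the scatter. Compound 4 `Cc1nc(NCc2ccncc2)nc(N[C@@H]2C[C@H](CO)[C@@H](O)[C@H]2O)c1-c1nc2ccccc2s1` differs from compound 3 by pyridin-4-yl in place of ethoxymethyl on a saturated chain carbon bound to a nitrogen on an aromatic ring. For the measured compounds named here, no measured step touches a saturated chain carbon bound to a nitrogen on an aromatic ring, so the measured steps give no guidance on this change, and a step within the scatter is expected. Compound 4 is estimated at 18000 nM, between 7000 nM and 40000 nM. This amounts to an expected step of no change at the digits printed from compound 3 to compound 4 (within the scatter).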

Compound 4, half-maximal cytotoxic concentration: 7000 nM
Beside the measured number, compound 4's estimate is 2.6-fold (0.41 log units) above it, and the stated range covers the measured number.
By their numbers in this assay, from the lowest: compounds 4, 2 and 3 (each within the scatter of the next, the first and the last beyond it). At a limit, above all of these: compound 1.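

In this assay, the first step read at this place shows that the side chain here can shift the result: a 2.6-fold lower number from compound 3 to compound 4 (0.41 log units; beyond the scatter) is seen with pyridin-4-yl in place of ethoxymethyl on a saturated chain carbon bound to a nitrogen on an aromatic ring. The lower number stands for higher toxicity in this test. Compound 1 alone stands at a limit, so this step joins two actual numbers: the limit of > 25000 nM in this assay, at which 1 of the 4 values shown sits.

The compounds shown leave open whether any aromatic ring here gives this shift or the ring nitrogen of pyridin-4-yl is needed. A phenyl group or a pyridin-3-yl group in the same place would begin to separate the two.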